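From 4-Fluorophenyl to Phenethyl: Expected Cytotoxicity of Compound 3

The source may hold more compounds than are shown below. What is called first, only, known or untested is meant among the compounds shown, and "the series" means these compounds.

Compound 1 `CCC1(Cc2ccccc2)OS(=O)(=O)C=C1OCc1ccc(F)cc1` — >= 50000 nM
Compound 2 `CCC1(Cc2ccccc2)OS(=O)(=O)CC1=O` — > 100000 nM

Compound 1 was tested in an ADME assay on HEL cells (Homo sapiens) for cytotoxicity, with a stated time of 3 days; a lower number here means that less compound is tolerated, a higher number that more compound is tolerated. In this assay compound 1 gives >= 50000 nM, which is a limit of the assay and not a number. In this assay compound 2 gives > 100000 nM, also a limit. Compound 1 therefore stands only at a limit, and the other value shown is a limit too (the limit of >= 50000 nM in this assay, at which 1 of the 2 values shown sits; (the limit of > 100000 nM in this assay, at which 1 of the 2 values shown sits)). Compound 3 `CCC1(Cc2ccccc2)OS(=O)(=O)C=C1OCCCc1ccccc1` differs from compound 1 by phenethyl in place of 4-fluorophenyl on a saturated chain carbon bound to an oxygen on an unsaturated carbon. Going by the values given here, no measured pair shows a change of this kind, so no step beyond the usual scatter is expected in this assay in either direction. Compound 3 is expected to give 50000 nM, between 30000 nM and 100000 nM. The expected step is a number no higher from compound 1 to compound 3 (the limit leaves the size open).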

Compound 3, minimum cytotoxic concentration: >= 20000 nM
Compound 3: only a limit was reported; the forecaster's own chance of this, stated with the estimate: 80%; the middle value lies beyond the limit too.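

In this assay compound 3 gives >= 20000 nM, which is a limit of the assay and not a number. Going by these compounds alone, no step from compound 1 to compound 3 can be read. The compounds shown leave open whether phenethyl in place of 4-fluorophenyl shifts the minimum cytotoxic concentration at all.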